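The source may report more compounds than this note shows. Statements on the series, on what has been measured and on what is new or still open speak of the compounds shown alone.

Measured so far in an assay on isolated protein for displacement of a labelled ligand from 5-hydroxytryptamine receptor 6 (Homo sapiens), read by scintillation counting, with a stated time of 1 h; a lower number here means a stronger inhibitor, a higher number a weaker inhibitor:
Compound 1, `CN(C)c1cn(S(=O)(=O)c2ccccc2)c2ccccc12`, gives 474 nM.
Compound 2, `O=S(=O)(c1ccccc1)n1cc(-c2ccccc2)c2ccccc21`, gives 146 nM.
Compound 3, `CN(C)c1ccc2c(ccn2S(=O)(=O)c2ccccc2)c1`, gives 82 nM.

Compound 1 and compound 2 differ in one place, (phenyl in place of dimethylamino on an aromatic carbon), and that change produced a 3.2-fold lower number from compound 1 to compound 2 (0.51 log units; beyond the scatter). Compound 3 has the same atoms as compound 1 joined differently; the difference between the two cores is not broken down here. Compound 3 and compound 2 lie within the usual scatter of each other in this assay.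

Compound 4, `O=S(=O)(c1ccccc1)n1ccc2cc(-c3ccccc3)ccc21`, is not yet measured. It differs from compound 3 by phenyl in place of dimethylamino on an aromatic carbon. This is the same kind of change as the one that gave a 3.2-fold lower number from compound 1 to compound 2 (0.51 log units; beyond the scatter), but not the same: there the group sat on a five-membered aromatic ring with 1 nitrogen, two ring bonds from the ring nitrogen; here it sits on a six-membered aromatic ring of carbon only, meta to a fused ring and para to a fused ring. A step in the same direction but smaller and less certain is therefore expected, estimated as a 1.5-fold lower number from compound 3 to compound 4 (0.17 log units; within the scatter). Compound 4 is expected to give about 55 nM in this assay, estimated between 15 nM and 220 nM.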

Compound 4, inhibition constant: 558 nM
Beside the measured number, compound 4's estimate is 10-fold (1.01 log units) below it; the whole stated range lies below it.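

In this assay, phenyl in place of dimethylamino on the six-membered aromatic ring of carbon only gave a 6.8-fold higher number from compound 3 to compound 4 (0.83 log units; beyond the scatter), opposite in direction to the earlier step. The result of this change therefore did not carry from one core to the other: the same change on two cores in this assay, a 3.2-fold lower number (0.51 log units; beyond the scatter) from compound 1 to compound 2 and a 6.8-fold higher number (0.83 log units; beyond the scatter) from compound 3 to compound 4, 22-fold (1.34 log units) apart, beyond the scatter of two such steps With only these two pairs, this shows that the outcome depends on the core, but it does not show what in the cores sets the difference or how the change would behave on any further core.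

The compounds shown leave open how other groups would fare on that same aromatic carbon, such as a cyclic amine like piperazine or a primary amine. They also leave open whether a methoxy group there would fall closer to dimethylamino or to phenyl.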